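One stereocentre flipped, still expected beyond the limit

A few compounds are considered here, and "the series" means these few. Any claim that something is new, unique, unknown or untested is made for them only; others in the source may bear on it.

compound 1 `O=C(/C=C/c1ccc(O)cc1)O[C@H]1[C@H](O[C@H]2CCCC[C@@H]2O)O[C@H](CO)[C@@H](O)[C@@H]1O`: > 10000 nM
compound 2 `O=C(/C=C\c1ccc(O)cc1)O[C@H]1[C@H](O[C@H]2CCCC[C@H]2O)O[C@H](CO)[C@@H](O)[C@@H]1O`: > 10000 nM

In a functional assay on HCT-15 cells (Homo sapiens) for cytotoxicity, read by sulforhodamine B assay (on this read-out higher numbers stand for weaker inhibition and lower numbers for stronger inhibition), compound 1 gives only a limit, > 10000 nM. Compound 2 likewise gives only a limit, > 10000 nM. Compound 3 `O=C(/C=C/c1ccc(O)cc1)O[C@H]1[C@H](O[C@@H]2CCCC[C@@H]2O)O[C@H](CO)[C@@H](O)[C@@H]1O` differs from compound 1 thus: the two compounds have the same atoms and bonds and differ only in configuration as drawn: 1 of 8 stereo elements differ; a stereocentre at a saturated ring carbon is drawn S in compound 1 and R in compound 3. For the measured compounds named here, the single measured step, a step that the two limits leave unreadable from compound 1 to compound 2, cannot be sized because of the limit of > 10000 nM in this assay, at which 2 of the 2 values shown sit, and it changes two stereo elements at once, so it gives no readable guide to a single flip. Compound 3 is therefore expected to remain at the limit, with an estimate of 20000 nM in a range of 8000 nM to 60000 nM. The step that the limit leaves unreadable from compound 1 to compound 3 is expected to stay within the usual scatter.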

Compound 3, half-maximal inhibitory concentration: > 10000 nM
Compound 3 was reported as a limit (the forecaster's own chance of this, stated with the estimate: 85%); the middle value does not contradict the limit.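

For the compounds shown here, no step among compound 1, compound 2 and compound 3 can be read, because all three values are limits and not numbers: (the limit of > 10000 nM in this assay, at which 3 of the 3 values shown sit). From the compounds shown here alone, how far any of these changes in configuration shifts the result in this assay stays open.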